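Aryl dimethyltriazenes: second carbamoyl on the ring

A few compounds are considered here, and "the series" means these few. Any claim that something is new, unique, unknown or untested is made for them only; others in the source may bear on it.

Measured so far in a functional assay on L1210 cells (Mus musculus) for antiproliferative activity; on this read-out higher numbers stand for higher potency (the scale is a negative logarithm) and lower numbers for lower potency:
- compound 1, `CN(C)/N=N/c1cccc(C(N)=O)c1`: 3.8
- compound 2, `Cc1cccc(/N=N/N(C)C)c1`: 3.4
- compound 3, `COc1ccc(C(N)=O)cc1/N=N/N(C)C`: 3.95

Compound 1 stands second highest of the three numbers in this assay. Its nearest neighbour is compound 3, reached by a number 0.15 log units higher from compound 1 to compound 3 (within the scatter) (methoxy in place of hydrogen on an aromatic carbon); its furthest is compound 2, reached by a number 0.40 log units lower from compound 1 to compound 2 (beyond the scatter) (methyl in place of carbamoyl on an aromatic carbon).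

The next compound is compound 4, `CN(C)/N=N/c1cc(C(N)=O)cc(C(N)=O)c1`, which differs from compound 1 as follows:

carbamoyl in place of hydrogen on an aromatic carbon

Among the compounds with values here, two measured steps bear on this change. The step from compound 1 to compound 2 shows that removing the carbamoyl in favour of methyl costs potency beyond the scatter, so a carbamoyl on the ring is, on this evidence, favourable. The step from compound 1 to compound 3 shows that adding a further substituent to the ring of compound 1 moves the number only within the scatter. Taken together, a second carbamoyl is expected to give at most a modest rise in this assay, and a result within the scatter would not be surprising.

For compound 4 the expected step from compound 1 is a number 0.20 log units higher from compound 1 to compound 4 (within the scatter), giving an estimated value of 4, with a range from 3.6 to 4.4.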

Compound 4, logarithm of the reciprocal of the active concentration, log(1/C): 3.27
Beside the measured number, compound 4's estimate is 0.73 log units above it; measured number below the stated range.
By their numbers in this assay, from the lowest: compounds 4 and 2 (each within the scatter of the next); then compounds 1 and 3 (each within the scatter of the next).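

In this assay a second carbamoyl, on the aromatic carbon meta to the first carbamoyl group, gives a number 0.53 log units lower from compound 1 to compound 4 (beyond the scatter) and so shows that this ring carbon of compound 1 does not tolerate every added group without a change in the number. Read with a number 0.40 log units lower from compound 1 to compound 2 (beyond the scatter) as the other step from compound 1, this places compound 1 above both neighbours: methyl in place of its carbamoyl lowers the number, and a further carbamoyl lowers it too, so the favourable reading of one carbamoyl does not extend to a second. Nothing measured here accounts for this fall.

On these data alone, whether the fall belongs to the carbamoyl itself or would follow any added group at this ring carbon remains open, and a nitrile, a carboxylic acid or an amine in the same place would help separate those readings. A methyl or a methoxy on this carbon, with the first carbamoyl kept, would show whether a smaller group leaves the number of compound 1 within the scatter.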